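The source may report more compounds than this note shows. Statements on the series, on what has been measured and on what is new or still open speak of the compounds shown alone.

Measured in a functional assay on A-375 cells (Homo sapiens) for activation, with a stated time of 3 days; on this read-out higher numbers stand for an effect only at larger amounts of compound and lower numbers for an effect already at smaller amounts:
- compound 1 `O=C(Nc1ccc(-c2cscn2)cc1)C1CCCN(C(=O)c2ccc(F)c(F)c2)C1`: > 20000 nM, a limit
- compound 2 `O=C(Nc1ccc(-c2cscn2)cc1)C1CCCN(S(=O)(=O)c2ccc(F)c(F)c2)C1`: > 20000 nM, a limit
- compound 3 `O=C(Nc1ccc(-c2cscn2)cc1)[C@@H]1CCCN(Cc2ccc(F)c(F)c2)C1`: 4000 nM

Compound 1 gives no number in this assay, only a limit. It sits with compound 2 at the limit of > 20000 nM in this assay, at which 2 of the 3 values shown sit. Only compound 3 gives a number, 4000 nM.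

The step followed here leads to compound 4 `O=C(Nc1ccc(-c2cscn2)cc1)C1CCCN(Cc2ccc(Cl)c(Cl)c2)C1`: 3,4-dichlorobenzyl in place of (3,4-difluorophenyl)carbonyl on an amine nitrogen in a ring. In words, 3,4-dichlorobenzyl stands in place of (3,4-difluorophenyl)carbonyl on an amine nitrogen in a ring.

For the measured compounds named here, no measured pair isolates this change, so the expectation rests on a single measured compound. Compound 3, at 4000 nM, is the closest measured structure to compound 4, and a value for compound 4 in the same region is expected. The expected move is well beyond the scatter and towards lower numbers, so an effect should appear at smaller amounts of compound. The estimated step is an at least 6.6-fold lower number from compound 1 to compound 4 (0.82 log units; beyond the scatter), and its true size stays uncertain since the starting point is only a limit. A limit for compound 4 also remains possible.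

For compound 4 the estimated value is 3000 nM, with an expected range from 700 nM to 14000 nM.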

Compound 4, half-maximal effective concentration: 3000 nM
The estimate for compound 4 equals the measured number at the digits printed; the measured number falls inside the stated range.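

The amine nitrogen in a ring now has a step that can be read: in this assay, 3,4-dichlorobenzyl in place of (3,4-difluorophenyl)carbonyl gives an at least 6.6-fold lower number from compound 1 to compound 4 (0.82 log units; beyond the scatter). Compound 1 gives > 20000 nM, which is a limit and not a number, and the same limit recurs in the series: the limit of > 20000 nM in this assay, at which 2 of the 4 values shown sit. This single step removes the carbonyl and exchanges fluorine for chlorine together, so it does not show which of the two parts carries the shift.

Still open, from the compounds shown here alone, is how other groups on this nitrogen would read in this assay, such as an unsubstituted benzyl, a 4-methoxybenzyl or a longer chain ending in a phenyl ring. Compound 3 is drawn with a defined configuration at the ring atom that bears a large group and compound 4 without one, so the role of that configuration also remains unresolved.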